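The source may hold more compounds than are shown below. What is called first, only, known or untested is meant among the compounds shown, and "the series" means these compounds.

Compound 1 `Cc1ccc(S(=O)(=O)Oc2ccc3c(c2C)[C@H](Cn2cc(-c4ccc(Cl)cc4)nn2)[C@@]24CC(=O)[C@@](C)(CC[C@@H]32)C4)cc1` — in a functional assay on SW480 cells (Homo sapiens) for cytotoxicity, read by MTT assay, with a stated time of 4 days (a higher number here means a weaker inhibitor, a lower number a stronger inhibitor), compound 1 gives > 20000 nM, which is a limit of the assay rather than a number.
Compound 2 `Cc1c(O)ccc2c1[C@H](Cn1cc(-c3ccc(C(F)(F)F)cc3)nn1)[C@@]13CC(=O)[C@@](C)(CC[C@@H]21)C3` — in this assay compound 2 gives > 20000 nM, again a limit and not a number.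

Among the measured compounds shown here, compound 2 therefore stands at the edge of what this assay can report: no potency value is known for it, and the only other value shown sits at the same edge, (the limit of > 20000 nM in this assay, at which 2 of the 2 values shown sit). Compound 3 `Cc1ccc(S(=O)(=O)Oc2ccc3c(c2C)[C@H](Cn2cc(-c4ccc(C(F)(F)F)cc4)nn2)[C@@]24CC(=O)[C@@](C)(CC[C@@H]32)C4)cc1` is not yet measured. It differs from compound 2 by (4-methylphenyl)sulfonyl in place of hydrogen on an oxygen on an aromatic ring. For the measured compounds named here, since no step between measured compounds exists here, the expectation rests only on the two limits, and the step from compound 2 to compound 3 is expected to be none beyond the scatter, a step that the limit leaves unreadable from compound 2 to compound 3. Compound 3 is estimated at 30000 nM in this assay, within a range of 15000 nM to 100000 nM, most likely reported only as a limit.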

Compound 3, half-maximal inhibitory concentration: > 20000 nM
Compound 3: a limit, no number (the forecaster's own chance of this, stated with the estimate: 85%); the middle value lies beyond the limit too.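

In this assay compound 3 gives > 20000 nM, a limit and not a number. Among the compounds shown here, no step to compound 3 can therefore be read from compound 1 or compound 2: the limit of > 20000 nM in this assay, at which 3 of the 3 values shown sit. The compounds shown leave open whether hydroxy to ((4-methylphenyl)sulfonyl)oxy, or chloro to trifluoromethyl, changes potency at all.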